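Swapping the indole for naphthalene at the amide nitrogen

A few compounds are considered here, and "the series" means these few. Any claim that something is new, unique, unknown or untested is made for them only; others in the source may bear on it.

Compound 1, `COc1ccc(Cl)cc1NC(=O)CN(c1cc(Cl)ccc1OC)S(=O)(=O)c1ccccc1`: > 20000 nM
Compound 2, `COc1ccccc1NC(=O)CN(c1cc(Cl)ccc1OC)S(=O)(=O)c1ccccc1`: 15500 nM
Compound 3, `CCn1ccc2cc(NC(=O)CN(c3cc(Cl)ccc3OC)S(=O)(=O)c3ccccc3)ccc21`: 2220 nM

All three were tested in a functional assay on SH-SY5Y cells (Homo sapiens), read by MTT assay, with a stated time of 24 h; a lower number here means that less compound is needed, a higher number that more compound is needed for the effect. Compound 1 sits at a limit of this assay, (the limit of > 20000 nM in this assay, at which 1 of the 3 values shown sits). Among the two numbers, compound 3 stands lowest; its nearest neighbour is compound 2, with a 7.0-fold lower number from compound 2 to compound 3 (0.84 log units; beyond the scatter). Compound 4, `COc1ccc(Cl)cc1N(CC(=O)Nc1cccc2ccccc12)S(=O)(=O)c1ccccc1`, is not yet measured and differs from compound 3 in one place: naphthalen-1-yl in place of 1-ethyl-1H-indol-5-yl on an amide-type nitrogen. For the measured compounds named here, two measured steps bear on this change, since each of them put the 1-ethyl-1H-indol-5-yl group onto the amide-type nitrogen in place of a single-ring group, and each lowered the number beyond the scatter: an at least 9.0-fold lower number from compound 1 to compound 3 (0.95 log units; beyond the scatter) and a 7.0-fold lower number from compound 2 to compound 3 (0.84 log units; beyond the scatter). Compound 4 keeps two fused aromatic rings at that place but carries no hetero atom there, so part of that gain is expected to remain. A modest rise in the number is therefore expected for compound 4, a 2.0-fold higher number from compound 3 to compound 4 (0.31 log units; beyond the scatter). The estimate for compound 4 is 4500 nM, with a range from 1500 nM to 14000 nM.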

Compound 4, half-maximal effective concentration: 17400 nM
Estimate against measurement, compound 4: 3.9-fold (0.59 log units) below, outside the stated range (above it).
By their numbers in this assay, from the lowest: compound 3; then compounds 2 and 4 (each within the scatter of the next). At a limit, above all of these: compound 1.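

At the amide-type nitrogen, two fused aromatic rings are not enough on their own: naphthalen-1-yl in place of 1-ethyl-1H-indol-5-yl takes back nearly all of the earlier gain (a 7.8-fold higher number from compound 3 to compound 4 (0.89 log units; beyond the scatter)). Naphthalen-1-yl in place of 2-methoxyphenyl at this nitrogen leaves the number within the scatter (a 1.1-fold higher number from compound 2 to compound 4 (0.05 log units; within the scatter)), so these two groups cannot be told apart here. Naphthalen-1-yl in place of 5-chloro-2-methoxyphenyl gives only a floor, and that floor lies within the scatter (an at least 1.1-fold lower number from compound 1 to compound 4 (0.06 log units; that floor lies within the scatter)). Compound 1 stands at a limit and not at a number: the limit of > 20000 nM in this assay, at which 1 of the 4 values shown sits.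

On these data alone, what remains open is which feature of 1-ethyl-1H-indol-5-yl matters: the five-membered ring with its nitrogen, or the ethyl group on it. A methyl group or a longer chain such as propyl in place of the ethyl, or an indole carrying only hydrogen on that nitrogen, would begin to separate the two.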